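Acetylpiperidine in Place of a Pyrazole Amide

A few compounds are considered here, and "the series" means these few. Any claim that something is new, unique, unknown or untested is made for them only; others in the source may bear on it.

Compound 1 `CNC(=O)c1cc(-c2cnc(NCc3c(F)ccc4c3CCO4)c3cn[nH]c(=O)c23)n(C)n1`: < 3 mL.min-1.g-1
Compound 2 `O=C(Nc1cnc(NCc2c(F)ccc3c2CCO3)n2cnnc12)c1ccccc1`: 10 mL.min-1.g-1
Compound 3 `Cc1ncccc1-c1cnc(NCc2c(F)ccc3c2CCO3)n2c(=O)[nH]nc12`: 36 mL.min-1.g-1

Three compounds sharing the same core have been run in an ADME assay on microsomes from liver (Homo sapiens) for metabolic stability, read by LC-MS, using NADPH, with stated times of 5 min and 30 min, tested at 1 uM; on this read-out lower numbers stand for slow clearance and higher numbers for fast clearance. For compound 1 the read-out is a limit of the assay rather than a number, (the limit of < 3 mL.min-1.g-1 in this assay, at which 1 of the 3 values shown sits), so compound 1 stands at the slow end of what was recorded. Among the measured compounds shown here, compound 3 gives 36 mL.min-1.g-1 in this assay, and compound 2 gives 10 mL.min-1.g-1; no single-point step connects any pair of these three, so their values are reported side by side without further comparison.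

Compound 4 `CC(=O)N1CCC(c2cnc(NCc3c(F)ccc4c3CCO4)c3cn[nH]c(=O)c23)CC1` differs from compound 1 in one place: 1-acetylpiperidin-4-yl in place of 1-methyl-3-(methylcarbamoyl)-1H-pyrazol-5-yl on an aromatic carbon. For the measured compounds named here, no measured step of this kind exists, so the change from compound 1 to compound 4 is expected to be small, an at least 1.6-fold higher number from compound 1 to compound 4 (0.22 log units; that floor lies within the scatter), not clearly beyond the scatter. Compound 4 is therefore expected to give 5 mL.min-1.g-1, with a range from 3 mL.min-1.g-1 to 15 mL.min-1.g-1.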

Compound 4, intrinsic clearance in microsomes: 207 mL.min-1.g-1
The estimate for compound 4 lay 41-fold (1.62 log units) below the measured number; the measured number lies above the stated range.
By their numbers in this assay, from the lowest: compound 2; then compound 3; then compound 4. At a limit, below all of these: compound 1.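

In this assay this position on the shared core proves highly sensitive to the group it carries: 1-acetylpiperidin-4-yl in place of 1-methyl-3-(methylcarbamoyl)-1H-pyrazol-5-yl gives an at least 69-fold higher number from compound 1 to compound 4 (1.83 log units; beyond the scatter) on this read-out. The earlier compounds shown here offered no single-place step, so none of them could show this. The step has only a lower bound, as compound 1 stands at a limit of the assay: the limit of < 3 mL.min-1.g-1 in this assay, at which 1 of the 4 values shown sits.

Going by these compounds, whether the non-aromatic ring, the acetyl group or the absent methylcarbamoyl drives the rise remains open. So does the behaviour of a morpholine or an unacetylated piperidine at this position.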